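This account rests on a few compounds, and the source may have more. Where it says the series, first, only, none or still open, it means among the compounds named here.

Working notes on the series, which so far has two measured compounds. In a physicochemical assay for lipophilicity, read by HPLC, at pH 7.4 (a higher number here means a more lipophilic compound, a lower number a more polar compound), compound 1 (`Cc1ccc([C@@H](C)Oc2cc3oc(=O)n(CCC(=O)O)c3cc2Cl)nc1`) gives 2.02 and compound 2 (`O=C(O)CCn1c(=O)oc2cc(OCC3CCC3)c(Cl)cc21`) gives 2.9 as the higher of the two numbers, a gap beyond the scatter. Within the data shown here, no measured step yet links two compounds that differ in one place. Next is compound 3 (`CC(C)Cc1cc2oc(=O)n(CCC(=O)O)c2cc1Cl`), still unmeasured, with isobutyl in place of cyclobutylmethoxy on an aromatic carbon, ortho to a chloro group. The count of that change reads isobutyl in place of cyclobutylmethoxy on an aromatic carbon in full. Among the measured compounds shown here, with no single-place step to scale from, the expectation rests on compound 2 at 2.9 alone, and any change in this assay is expected to stay within the scatter. The expected move is a number 0.10 log units lower from compound 2 to compound 3 (within the scatter) in this estimate. In this assay compound 3 is estimated at 2.8 with 2.4 to 3.2 as the expected range.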

Compound 3, distribution coefficient: 3.03
For compound 3 the middle estimate is 0.23 log units below the measured one, and the stated range covers the measured number.
By their numbers in this assay, from the lowest: compound 1; then compounds 2 and 3 (each within the scatter of the next).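

Among these compounds, the step of a number 0.13 log units higher from compound 2 to compound 3 (within the scatter) is the first single-place comparison in this assay, and it concerns the aromatic carbon ortho to a chloro group. The cyclobutylmethoxy that leaves carries one oxygen, one hydrogen-bond acceptor and a four-membered ring, the isobutyl that enters carries none of these and has fewer heavy atoms, yet compound 2 and compound 3 cannot be told apart in this read-out. Nothing on hand gives a reason for this result.

The compounds shown leave open how an amine or a hydroxyl group on this same aromatic carbon would read in this assay. As far as these compounds go, a longer alkyl chain in place of isobutyl is also open, as is whether its reading would stay within the scatter of compound 3.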